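A few compounds are considered here, and "the series" means these few. Any claim that something is new, unique, unknown or untested is made for them only; others in the source may bear on it.

Measured in a functional assay on PC-3 cells (Homo sapiens) for cytotoxicity, read by MTT assay, with a stated time of 72 h; a higher number here means a weaker inhibitor, a lower number a stronger inhibitor:
compound 1 `O=S(=O)(c1ccccc1)c1nc2ccccc2nc1Nc1ccccc1`: 590 nM
compound 2 `COc1cc(Nc2nc3ccccc3nc2S(=O)(=O)c2ccccc2)cc(OC)c1`: 140 nM
compound 3 `Nc1cccc(Nc2nc3ccccc3nc2S(=O)(=O)c2ccccc2)c1`: 2150 nM

Compound 3 gives the highest number of the three: a 3.6-fold higher number from compound 1 to compound 3 (0.56 log units; beyond the scatter) and a 15-fold higher number from compound 2 to compound 3 (1.19 log units; beyond the scatter) both set it apart, beyond the scatter. Compound 4 `Nc1cccc(Nc2nc3ccccc3nc2S(=O)(=O)c2ccc(F)cc2)c1` keeps the whole of compound 3 and differs only in that (fluoro in place of hydrogen on an aromatic carbon). Every measured step, a 4.2-fold lower number from compound 1 to compound 2 (0.62 log units; beyond the scatter) among them, alters the group on the nitrogen, not the phenyl that here becomes 4-fluorophenyl; none bears on this change. With nothing to guide it, the step expected in this assay is none beyond the scatter, and the step expected for compound 4 is a 1.1-fold lower number from compound 3 to compound 4 (0.03 log units; within the scatter). The estimate for compound 4 is 2000 nM, with a range from 900 nM to 4500 nM.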

Compound 4, half-maximal inhibitory concentration: 1980 nM
Compound 4: middle estimate off by 1.0-fold (0.00 log units), on the high side, within the range that was stated.
By their numbers in this assay, from the lowest: compound 2; then compound 1; then compounds 4 and 3 (each within the scatter of the next).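

Fluoro in place of hydrogen, para to a large group, gives a 1.1-fold lower number from compound 3 to compound 4 (0.04 log units; within the scatter) in this assay and so leaves the number within the scatter at a place that the earlier compounds did not touch. This holds only for the phenyl to 4-fluorophenyl change with the 3-aminophenyl group on the nitrogen. No measured evidence bears on this result.

On these data alone, whether a carboxylic acid or an amine at this place would also stay within the scatter remains open. So does whether fluoro would do the same alongside the 3,5-dimethoxyphenyl group of compound 2.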